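The source may report more compounds than this note shows. Statements on the series, on what has been measured and on what is new or still open speak of the compounds shown alone.

In an ADME assay on Vero cells (Chlorocebus sabaeus) for cytotoxicity, with a stated time of 72 h (on this read-out lower numbers stand for stronger inhibition and higher numbers for weaker inhibition), three compounds with the same shared core have been examined so far. Compound 1 `O=[N+]([O-])c1cn2c(n1)OC[C@@H](OCc1cccc(-c3ccc(C(F)(F)F)cc3)c1)C2` returns only a limit of the assay, > 128000 nM. Compound 2 `N#Cc1ccc(-c2cccc(CO[C@@H]3COc4nc([N+](=O)[O-])cn4C3)c2)cc1` likewise gives only a limit, > 128000 nM. Compound 3 `O=[N+]([O-])c1cn2c(n1)OC[C@@H](OCc1csc(-c3ccc(C(F)(F)F)cc3)n1)C2` also stops at a limit, > 128000 nM. Between compound 1 and compound 2 the change is cyano in place of trifluoromethyl on an aromatic carbon, and the step that the two limits leave unreadable from compound 1 to compound 2 cannot be read because of the limit of > 128000 nM in this assay, at which 3 of the 3 values shown sit. How the core of compound 3 differs from that of compound 1 is not broken down here.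

Compound 4 `N#Cc1ccc(-c2nc(CO[C@@H]3COc4nc([N+](=O)[O-])cn4C3)cs2)cc1` has not yet been measured in this assay. It differs from compound 3 by cyano in place of trifluoromethyl on an aromatic carbon, the same change that separates compound 1 from compound 2, at a place described in the same words. Since the earlier step from compound 1 to compound 2 could not be sized, nothing in the measured pairs points to a direction. Compound 3 is expected to pass to compound 4 by an estimated step that the limit leaves unreadable from compound 3 to compound 4. Compound 4 is therefore expected to give about 200000 nM, between 100000 nM and 400000 nM.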

Compound 4, half-maximal inhibitory concentration: > 128000 nM
Compound 4 gave a limit, no number (the forecaster's own chance of this, stated with the estimate: 90%); the middle value does not contradict the limit.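

No step can be read from compound 3 to compound 4 in this assay, since compound 4, like compound 3, returns only a limit: the limit of > 128000 nM in this assay, at which 4 of the 4 values shown sit. The compounds shown leave open whether cyano in place of trifluoromethyl on an aromatic carbon changes the read-out at all, and where the actual values of all four compounds lie.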